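Compound 4: a new group where clearance has varied

The source may report more compounds than this note shows. Statements on the series, on what has been measured and on what is new or still open speak of the compounds shown alone.

Compound 1 `Nc1ccc(S(=O)(=O)N2CCN(c3ncc(C(O)(C(F)(F)F)C(F)(F)F)cc3C#CCO)CC2)cn1`: 65 mL.min-1.g-1
Compound 2 `Cn1cc(-c2cc(C(O)(C(F)(F)F)C(F)(F)F)cnc2N2CCN(S(=O)(=O)c3ccc(N)nc3)CC2)cn1`: 44 mL.min-1.g-1
Compound 3 `Cc1ccc(-c2cc(C(O)(C(F)(F)F)C(F)(F)F)cnc2N2CCN(S(=O)(=O)c3ccc(N)nc3)CC2)cn1`: 182 mL.min-1.g-1

These three compounds were measured in an ADME assay (liver) for metabolic stability, with Liver microsome (Rattus norvegicus) as the target, using microsomes and NADPH, with a stated time of 30 min, tested at 1 uM (a higher number here means faster removal of the compound, a lower number slower removal), and differ only in one group on the shared core. Compound 3 stands highest of the three at 182 mL.min-1.g-1. Both steps that reach it lie beyond the scatter: a 2.8-fold higher number from compound 1 to compound 3 (0.45 log units; beyond the scatter) and a 4.1-fold higher number from compound 2 to compound 3 (0.62 log units; beyond the scatter). The remaining step, a 1.5-fold lower number from compound 1 to compound 2 (0.17 log units; within the scatter), does not separate the other two.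

Compound 4 `Nc1ccc(S(=O)(=O)N2CCN(c3ncc(C(O)(C(F)(F)F)C(F)(F)F)cc3-c3ccc4[nH]ncc4c3)CC2)cn1` keeps the core of compound 3 and changes that same group: 1H-indazol-5-yl in place of 6-methylpyridin-3-yl on an aromatic carbon. Here 1H-indazol-5-yl takes the place of 6-methylpyridin-3-yl on an aromatic carbon, ortho to a large group. Among the compounds with values here, no measured step involves 1H-indazol-5-yl, so the evidence is only indirect. The closest guide is the exchange between 1-methyl-1H-pyrazol-4-yl and 6-methylpyridin-3-yl, a 4.1-fold higher number from compound 2 to compound 3 (0.62 log units; beyond the scatter), and the largest step seen at this position. Compound 3 also sits at the top of the measured range, and neither other group reaches its number, so a modest fall is more likely than a further rise. The expected change is a 1.8-fold lower number from compound 3 to compound 4 (0.26 log units; within the scatter), though the wide range leaves either direction open. For compound 4 the estimated value is 100 mL.min-1.g-1, with an expected range of 40 mL.min-1.g-1 to 250 mL.min-1.g-1.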

Compound 4, intrinsic clearance in microsomes: 88 mL.min-1.g-1
Beside the measured number, compound 4's estimate is 1.1-fold (0.06 log units) above it; the measured number falls inside the stated range.
By their numbers in this assay, from the lowest: compounds 2, 1 and 4 (each within the scatter of the next); then compound 3.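

In this assay, 1H-indazol-5-yl shows that compound 3 stands apart from all the other compounds at this position, not just from the first two: a 2.1-fold lower number from compound 3 to compound 4 (0.32 log units; beyond the scatter) joins the two earlier steps beyond the scatter that reach compound 3. The same group, with one five-membered and one six-membered aromatic ring and a hydrogen-bond donor that 6-methylpyridin-3-yl lacks, does not separate from the other two groups, with a 2.0-fold higher number from compound 2 to compound 4 (0.30 log units; within the scatter) and a 1.4-fold higher number from compound 1 to compound 4 (0.13 log units; within the scatter), so three quite different groups now lie within the scatter of their neighbours and only 6-methylpyridin-3-yl lies beyond it. Nothing measured on these compounds accounts for this difference.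

The compounds shown leave open whether the high number of compound 3 goes with the methyl group or with the pyridine ring itself, a question that an unsubstituted pyridin-3-yl or a 6-methoxypyridin-3-yl at the same carbon would address. They also leave open what the ring hydrogen on nitrogen of 1H-indazol-5-yl contributes, which 1-methyl-1H-indazol-5-yl would show when set against compound 4.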